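A few compounds are considered here, and "the series" means these few. Any claim that something is new, unique, unknown or untested is made for them only; others in the source may bear on it.

Compound 1, `NC(=O)c1c(NC(=O)c2ccccc2Cl)sc2c1CCN(C(=S)Nc1ccccc1F)C2`, gives 4970 nM in a functional assay on HL-60 cells (Homo sapiens) for antiproliferative activity, with a stated time of 24 h; on this read-out higher numbers stand for weaker inhibition and lower numbers for stronger inhibition.
Compound 2, `NC(=O)c1c(NC(=O)c2ccccc2C(F)(F)F)sc2c1CCN(C(=S)Nc1ccccc1F)C2`, gives 23500 nM in this assay.

Compound 2 gives the higher of the two numbers: the step of a 4.7-fold higher number from compound 1 to compound 2 (0.67 log units; beyond the scatter) separates it from compound 1. Compound 3, `COc1ccccc1NC(=S)N1CCc2c(sc(NC(=O)c3ccccc3C(F)(F)F)c2C(N)=O)C1`, differs from compound 2 by methoxy in place of fluoro on an aromatic carbon. Within the data shown here, no measured step bears on this change: the only step recorded, from compound 1 to compound 2, sits on the other aromatic ring and concerns a trifluoromethyl in place of chloro, which says nothing about the amino-bearing ring of the thiourea. Among the measured compounds shown here, with no step of the same kind to lean on, compound 3 is expected to stay close to compound 2, and the estimated step of a 1.0-fold lower number from compound 2 to compound 3 (0.01 log units; within the scatter) is therefore expected not to exceed the scatter in either direction. Compound 3 is estimated at 23000 nM in this assay, with a range from 7000 nM to 70000 nM.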

Compound 3, half-maximal inhibitory concentration: > 50000 nM
Compound 3 ended at the assay's limit; the forecaster's own chance of this, stated with the estimate: 10%; at least 2.1-fold (0.33 log units) between middle value and limit.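

Among these compounds, replacing 2-fluorophenyl with 2-methoxyphenyl on the thiourea gives an at least 2.1-fold higher number from compound 2 to compound 3 (0.32 log units; beyond the scatter) in this assay, the first sign that this aromatic ring, unchanged between the earlier compounds, does not tolerate every group equally. Compound 3 stands at a limit of the assay and not at a number: the limit of > 50000 nM in this assay, at which 1 of the 3 values shown sits. Only a lower bound on this step can be read, but it runs the same way as the change on the other aromatic ring, a 4.7-fold higher number from compound 1 to compound 2 (0.67 log units; beyond the scatter).

The compounds shown do not tell how a hydroxy or an amino group would fare in place of methoxy. They also leave open whether methoxy would carry the same cost with the chloro of compound 1 on the other aromatic ring.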